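Fluoro to chloro on the fused core, compound 3 to compound 4

The source may hold more compounds than are shown below. What is called first, only, known or untested is meant among the compounds shown, and "the series" means these compounds.

Measured compounds:
compound 1, `CCCCN(CC)c1cc(C)nc2c(-c3cnc(N(C)C)cc3C)c(C)nn12`: 2.6 nM
compound 2, `CCCN(CCC)c1cc(C)nc2c(-c3cnc(C)cc3C)c(C)nn12`: 7.3 nM
compound 3, `CCCN(CCC)c1c(F)c(C)nc2c(-c3cnc(N(C)C)cc3C)c(C)nn12`: 5.6 nM

All three were run in an assay on CHO cells for binding affinity to corticotropin-releasing factor receptor 1 (Homo sapiens); a lower number here means a stronger inhibitor, a higher number a weaker inhibitor. Compound 3 holds the second highest number of the three. Its nearest neighbour is compound 2, whose number lies within the scatter of that of compound 3, so the two cannot be ordered. Compound 1 stands at a lower number than compound 3, a gap beyond the scatter.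

Compound 4, `CCCN(CCC)c1c(Cl)c(C)nc2c(-c3cnc(N(C)C)cc3C)c(C)nn12`, is the next compound in line. Against compound 3 the change is chloro in place of fluoro on an aromatic carbon. The ring and the attached groups are otherwise unchanged, and the rest of the molecule is kept.

For the measured compounds named here, no measured pair in this set isolates a halogen swap of this kind, so the step has to be guessed. The expectation is a small change, within or close to the scatter, leaning toward a slightly lower number; the estimated step from compound 3 to compound 4 in this assay is a 1.4-fold lower number from compound 3 to compound 4 (0.15 log units; within the scatter). Compound 4 is therefore expected to give about 4 nM in this assay, within a range from 1.5 nM to 12 nM.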

Compound 4, inhibition constant: 39 nM
Estimate against measurement, compound 4: 9.8-fold (0.99 log units) below, and the stated range ends below it.
By their numbers in this assay, from the lowest: compound 1; then compounds 3 and 2 (each within the scatter of the next); then compound 4.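

In this assay, the halogen on this carbon is not interchangeable: chloro in place of fluoro gives a 7.0-fold higher number from compound 3 to compound 4 (0.84 log units; beyond the scatter). For the compounds shown here, this is the first step that reads one place alone, and it shows that a swap of one heavy atom, with no change in the counted hydrogen-bond donors or acceptors, can move the number beyond the scatter at this carbon, ortho to the dipropylamino group and ortho to the methyl group. No measurement at hand bears on what lies behind this step.

Still open, from the compounds shown here alone, is how a bromo, methyl or methoxy group would read on this carbon. Going by these compounds, the effect of either halogen against plain hydrogen also stays open, as compounds 1 and 2 carry hydrogen there but differ elsewhere as well.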